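The source may hold more compounds than are shown below. What is called first, only, known or untested is meant among the compounds shown, and "the series" means these compounds.

Measured so far in a functional assay on HepG2 cells (Homo sapiens) for inhibition, read by MTT assay, with a stated time of 72 h; on this read-out higher numbers stand for weaker inhibition and lower numbers for stronger inhibition:
compound 1 `Nc1ncn(CCC2(N)OC(=O)C(OCc3ccccc3)=C2OCc2ccccc2)c(=O)n1` gives > 100000 nM, a limit of this assay.
compound 2 `NC1(CCn2cc(F)c(=O)[nH]c2=O)OC(=O)C(OCc2ccccc2)=C1OCc1ccccc1` gives 42800 nM.
compound 3 `NC1(CCn2ccc(=O)[nH]c2=O)OC(=O)C(OCc2ccccc2)=C1OCc1ccccc1` gives > 100000 nM, again a limit.

Compound 3 therefore stands at the top end of what this assay can report; its value is a limit and not a number. Compound 1 sits at the same limit (the limit of > 100000 nM in this assay, at which 2 of the 3 values shown sit). Only compound 2 carries a number. The step of an at least 2.3-fold higher number from compound 2 to compound 3 (0.36 log units; beyond the scatter) is readable; the step of an at least 2.3-fold lower number from compound 1 to compound 2 (0.36 log units; beyond the scatter) likewise; the step that the two limits leave unreadable from compound 1 to compound 3 is not, since both ends are limits.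

Compound 4 `Nc1ccn(CCC2(N)OC(=O)C(OCc3ccccc3)=C2OCc2ccccc2)c(=O)n1` differs from compound 3 by a group of 8 heavy atoms (4 carbon, 3 nitrogen, 1 oxygen; one six-membered aromatic ring with 2 hetero atoms) in place of a group of 8 heavy atoms (4 carbon, 2 nitrogen, 2 oxygen; one six-membered aromatic ring with 2 hetero atoms), on a saturated chain carbon, two bonds along the chain from a saturated ring carbon. Among the compounds with values here, no measured step exchanges this ring for the one entering here, so the nearest guide is the pair compound 1 and compound 3, both at the limit, against compound 2, which alone falls below it. A step of no readable size is expected, a number no higher from compound 3 to compound 4 (the limit leaves the size open). Compound 4 is expected to give about 100000 nM, between 40000 nM and 300000 nM, most likely reported as a limit again.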

Compound 4, half-maximal inhibitory concentration: > 100000 nM
Compound 4 gave a limit, no number; the forecaster's own chance of this, stated with the estimate: 75%; the middle value lies on the limit itself.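

In this assay compound 4 gives > 100000 nM, a limit of the assay and not a number. The ring entering here does not share the measurable activity of the fluoro-bearing ring, with an at least 2.3-fold higher number from compound 2 to compound 4 (0.36 log units; beyond the scatter). The steps linking compound 4 to compound 1 and compound 3 cannot be read, since both ends are limits, and the series now sits mostly at one ceiling: the limit of > 100000 nM in this assay, at which 3 of the 4 values shown sit.

On these data alone, how far the rings of compound 1, compound 3 and compound 4 differ from one another stays open, since all three sit at the limit. Also open, as far as these compounds go, is whether chloro or methyl in place of the hydrogen on the aromatic carbon of compound 3, or a longer chain to the ring, would yield a number.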